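The source may report more compounds than this note shows. Statements on the series, on what has been measured and on what is new or still open speak of the compounds shown alone.

Compound 2 `CS(=O)(=O)c1ccc(-c2oc3ccccc3c(=O)c2-c2ccc(F)cc2)cc1` is the starting point of this step. In an assay on isolated protein for inhibition of prostaglandin G/H synthase 1 (Mus musculus), tested at 10 ug/mL (a higher number here means more inhibition at the concentration tested (going by the name of the read-out), a lower number less inhibition), compound 2 gives only a limit, < 8%. Compound 1 `CS(=O)(=O)c1ccc(-c2oc3ccccc3c(=S)c2-c2ccc(F)cc2)cc1` likewise gives only a limit in this assay, < 5%. Compound 3 `CS(=O)(=O)c1ccc(-c2oc3ccccc3c(=S)c2-c2ccccc2)cc1` also reaches only a limit in this assay, < 5%. For the measured compounds named here, the one change among the measured compounds, a step that the two limits leave unreadable from compound 1 to compound 3, cannot be sized, since both ends are limits. Compound 4 `Cc1ccccc1-c1c(-c2ccc(S(C)(=O)=O)cc2)oc2ccccc2c1=O` differs from compound 2 by 2-methylphenyl in place of 4-fluorophenyl on an aromatic carbon. Going by the values given here, no measured step bears on this change, and every value shown sits at a limit, the limit of < 5% in this assay, at which 2 of the 3 values shown sit, or (the limit of < 8% in this assay, at which 1 of the 3 values shown sits). Compound 4 is therefore expected to stay at the same floor, at an estimated 5%, within 0% to 15%. The step this estimate implies, a step that the limit leaves unreadable from compound 2 to compound 4, is expected to be no larger than the scatter.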

Compound 4, a percentage reported as inhibition, at one concentration (the size of the read-out at that concentration, not a potency): < 5%
Compound 4 was reported as a limit; the forecaster's own chance of this, stated with the estimate: 70%; the middle value lies on the limit itself.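

For the compounds shown here, compound 2 and compound 4 are both reported only as limits in this assay, and no step between them can be read. The compounds shown leave open how 2-methylphenyl and 4-fluorophenyl truly compare in inhibition.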